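Phenyl-to-methyl swap on two fused cores

The source may report more compounds than this note shows. Statements on the series, on what has been measured and on what is new or still open speak of the compounds shown alone.

Measured so far in an assay on isolated protein for inhibition of MAP kinase-activated protein kinase 2 (Homo sapiens), read by mobility shift assay, tested at 30 uM; a higher number here means more inhibition at the concentration tested (going by the name of the read-out), a lower number less inhibition:
compound 1 `Cc1cc2nn(-c3ccccc3)c(N)c2c(=O)[nH]1` gives -4%
compound 2 `Nc1c2c(=O)[nH]c(-c3ccccc3)cc2nn1-c1ccccc1` gives 2%
compound 3 `Cc1cc2nc(-c3ccccc3)nc(N)c2c(=O)[nH]1` gives 22%

Compound 3 stands highest of the three, and its gaps to compound 2 and to compound 1 are both beyond the scatter. How the core of compound 3 differs from the core of compound 2 is not broken down here.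

From compound 2 to compound 1 the change is methyl in place of phenyl on an aromatic carbon; the step was a number 6 percentage points lower from compound 2 to compound 1 (within the scatter).

Compound 4 `Cc1nc(N)c2c(=O)[nH]c(C)cc2n1` is not yet measured. From compound 3 to compound 4 the change is methyl in place of phenyl on an aromatic carbon. This is the same kind of change as from compound 2 to compound 1, but the place differs: in compound 3 the carbon sits in a ring with 2 nitrogen, between two ring nitrogen atoms and meta to an amino group, whereas in compound 2 it sits in a ring with 1 nitrogen, next to the ring nitrogen.

For compound 4 a step of about a number 7 percentage points lower from compound 3 to compound 4 (within the scatter) in this assay is expected, resting on the small step seen from compound 2 to compound 1, a number 6 percentage points lower from compound 2 to compound 1 (within the scatter). Compound 4 is therefore estimated at 15%, with a range from 0% to 30%.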

Compound 4, a percentage reported as inhibition, at one concentration (the size of the read-out at that concentration, not a potency): 18%
The estimate for compound 4 lay 3 percentage points below the measured number; measured number inside the range.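

Methyl in place of phenyl on an aromatic carbon of the core of compound 3 gives, in this assay, a number 4 percentage points lower from compound 3 to compound 4 (within the scatter). On the two cores shown, the change therefore behaves alike, with no step beyond the scatter and no difference between the two steps: the same change on two cores in this assay, a number 6 percentage points lower (within the scatter) from compound 2 to compound 1 and a number 4 percentage points lower (within the scatter) from compound 3 to compound 4, 2 percentage points apart, within the scatter of two such steps

This shows only that the phenyl can give way to methyl on these two cores without a readable step in this assay; it does not show that the same would hold on other cores, at other places, or at other concentrations, since the read-out comes from one concentration and all four numbers stay modest.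

As far as these compounds go, whether any other group on this aromatic carbon, such as a longer chain, an amine or a carboxylic acid, would move the number beyond the scatter stays open. Also open, from the compounds shown here alone, is what happens on these cores when the amino group, common to all four compounds, gives way to another group.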